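Hydrazone aryl swap: cytotoxicity expectation for compound 4

This account rests on a few compounds, and the source may have more. Where it says the series, first, only, none or still open, it means among the compounds named here.

Three hydrazones on the shared core have been measured in an ADME assay on NIH3T3 cells (Mus musculus) for cytotoxicity, read by MTT assay, with a stated time of 24 h; a higher number here means a weaker inhibitor, a lower number a stronger inhibitor: compound 1 `O=C(CSc1nnc(-c2ccncc2)o1)N/N=C/c1ccc(Cl)cc1` gives 181000 nM, compound 2 `Cc1ccc(/C=N/NC(=O)CSc2nnc(-c3ccncc3)o2)cc1` gives 185000 nM, and compound 3 `O=C(CSc1nnc(-c2ccncc2)o1)N/N=C/c1cccc(C(F)(F)F)c1` gives 169000 nM. Compound 2 sits alongside compound 1 and compound 3, with all three numbers within the usual scatter of one another, so no ordering among them can be read from these values. Within the data shown here, the single one-place step available, a 1.0-fold higher number from compound 1 to compound 2 (0.01 log units; within the scatter), shows that swapping the substituent on the aromatic ring did nothing beyond the scatter, and compound 3 with its trifluoromethyl group lands in the same region.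

Compound 4 `O=C(CSc1nnc(-c2ccncc2)o1)N/N=C/c1cc(Cl)ccc1O` introduces the change (5-chloro-2-hydroxyphenyl in place of 4-methylphenyl on a carbon with a double bond to nitrogen), which adds a hydroxyl bearing 1 hydrogen-bond donor and 1 hydrogen-bond acceptor. Among the measured compounds shown here, no measured step covers a hydroxyl on this ring, so only the flat behaviour of compound 1, compound 2 and compound 3 informs the expectation. In this assay the expected step is a 1.1-fold lower number from compound 2 to compound 4 (0.02 log units; within the scatter), that is none beyond the scatter. Compound 4 is therefore estimated at 175000 nM, within a range of 90000 nM to 350000 nM.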

Compound 4, half-maximal inhibitory concentration: 166000 nM
The estimate for compound 4 lay 1.1-fold (0.02 log units) above the measured number; the range from low to high includes it.
By their numbers in this assay, from the lowest: compounds 4, 3, 1 and 2 (each within the scatter of the next).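

In this assay the aryl group on the carbon with a double bond to nitrogen now carries a hydroxyl, and the number stays flat: the result is a 1.1-fold lower number from compound 2 to compound 4 (0.05 log units; within the scatter) and a 1.1-fold lower number from compound 1 to compound 4 (0.04 log units; within the scatter) against the chloro-substituted comparator. Among these compounds, the 5-chloro-2-hydroxyphenyl group brings a hydrogen-bond donor and acceptor that 4-methylphenyl lacks, so at this position, across these four compounds, adding them produces no step beyond the scatter, which the earlier compounds could not show. No supporting data bear on the reason for this flat result.

On these data alone, all four compounds carry an uncharged aryl group here, so it remains open whether an amine or a carboxylic acid on this ring would move the number out of this region. As far as these compounds go, the effect of a longer chain in place of the ring at this position, and of any change elsewhere on the shared core, also remains open.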